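Swapping the aryl halide on a fused bicyclic core

The compounds below may be only part of what the source reports. "The series", "measured", "known", "first", "only" and "open" are said of these compounds alone.

Compound 1, `Brc1cn2ccnc2c(-c2ccc3ncn(C4CCCCC4)c3c2)n1`: 8.82%
Compound 2, `COc1ccc(-c2cn3ccnc3c(-c3ccc4ncn(C5CCCCC5)c4c3)n2)cc1`: 87.2%
Compound 3, `Brc1ccc(-c2cn3ccnc3c(-c3ccc4ncn(C5CCCCC5)c4c3)n2)cc1`: 30.5%

In a functional assay on NCI/ADR-RES cells (Homo sapiens) for inhibition, read by sulforhodamine B assay, with a stated time of 48 h, tested at 10 uM (a higher number here means more inhibition at the concentration tested (going by the name of the read-out), a lower number less inhibition), compound 3 stands second highest of the three, beyond the scatter from both neighbours. The step of a number 21.7 percentage points higher from compound 1 to compound 3 (beyond the scatter) was modest, whereas a number 56.7 percentage points lower from compound 2 to compound 3 (beyond the scatter) was large, so the aryl substituent matters strongly here. Compound 4, `Fc1ccccc1-c1cn2ccnc2c(-c2ccc3ncn(C4CCCCC4)c3c2)n1`, carries 2-fluorophenyl in place of 4-bromophenyl on an aromatic carbon. Among the measured compounds shown here, no measured step pairs a halogen with a fluorine, nor shifts the ring substituent position, so the direction is uncertain; both known steps onto or off compound 3 were real but of differing size. The step of a number 4.5 percentage points higher from compound 3 to compound 4 (within the scatter) is expected to stay small. Compound 4 is estimated at 35%, within 10% to 75%.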

Compound 4, a percentage reported as inhibition, at one concentration (the size of the read-out at that concentration, not a potency): 4.51%
For compound 4 the middle estimate is 30.5 percentage points above the measured one; measured number below the stated range.
By their numbers in this assay, from the lowest: compounds 4 and 1 (each within the scatter of the next); then compound 3; then compound 2.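

In this assay, an aryl group at this position does not by itself bring inhibition: the step with 2-fluorophenyl replacing 4-bromophenyl is a number 26 percentage points lower from compound 3 to compound 4 (beyond the scatter), and with it replacing 4-methoxyphenyl, a number 82.7 percentage points lower from compound 2 to compound 4 (beyond the scatter). Against the bromo group the step is a number 4.3 percentage points lower from compound 1 to compound 4 (within the scatter), so the two cannot be told apart, and compound 4 goes against the gain that both earlier aryl groups showed over bromo. Nothing measured here gives a reason for these differences. The compounds shown leave open whether the fall follows from the fluorine or from where it sits on the phenyl ring. From the compounds shown here alone, how an amine on that ring would behave also remains open.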